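A third group on the carbonyl carbon

This account rests on a few compounds, and the source may have more. Where it says the series, first, only, none or still open, it means among the compounds named here.

Compounds measured so far in an ADME assay on microsomes from liver (Mus musculus) for metabolic stability, read by LC-MS, with a stated time of 30 min, tested at 1 uM; a lower number here means that less of the compound is left, a higher number that more of the compound is left
- compound 1 `O=C(NCc1ccc(S(=O)(=O)c2ccccc2)cc1)c1nc2cnccc2[nH]1` gives 7.3%
- compound 2 `O=C(NCc1ccc(S(=O)(=O)c2ccccc2)cc1)c1cn2ccnc2cn1` gives 13%

Among the compounds with values here, these are the only two numbers available, and they cannot be told apart. Compound 2 gives 13% and stands level with compound 1 once the usual scatter is allowed for.

Compound 3 `O=C(NCc1ccc(S(=O)(=O)c2ccccc2)cc1)c1c[nH]c2ccncc12` has not yet been measured. Within the data shown here, it differs from compound 2 only in the group on the carbonyl carbon, the one whose other neighbour is an amide-type nitrogen. The change is this: a group of 9 heavy atoms (7 carbon, 2 nitrogen; one five-membered aromatic ring with 1 hetero atom, one six-membered aromatic ring with 1 hetero atom) in place of a group of 9 heavy atoms (6 carbon, 3 nitrogen; one five-membered aromatic ring with 2 hetero atoms, one six-membered aromatic ring with 2 hetero atoms), on a carbonyl carbon.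

Among the measured compounds shown here, one measured step bears on it, because it was made at the same place: a number 5.7 percentage points higher from compound 1 to compound 2 (within the scatter). That step stayed within the scatter, but a single step is thin evidence, and the group entering here has not been measured in any other compound. No large move is therefore expected in this assay. The expected result is a number 3 percentage points lower from compound 2 to compound 3 (within the scatter), which is no move beyond the scatter.

The estimate for compound 3 is 10%, with the expected range running from 2% to 25%.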

Compound 3, percent of the compound remaining: 45%
Compound 3: the middle estimate sits 35 percentage points below what was measured; the whole stated range lies below it.
By their numbers in this assay, from the lowest: compounds 1 and 2 (each within the scatter of the next); then compound 3.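

In this assay, within the data shown here, the group on the carbonyl carbon turns out to matter a great deal: the third group gives a number 32 percentage points higher from compound 2 to compound 3 (beyond the scatter) and likewise a number 37.7 percentage points higher from compound 1 to compound 3 (beyond the scatter), while the one earlier step at this place gave no hint of such a move. All three groups have the same number of heavy atoms and pair a five-membered with a six-membered aromatic ring, so this large rise comes with a swap of ring nitrogen for carbon at unchanged group size, with one hetero atom in each ring of the group in compound 3. Nothing measured here explains why the number rises.

On these data alone, it remains open whether the rise would continue with no nitrogen at all in the six-membered ring, as in an indole group, or whether a plain phenyl group on the carbonyl carbon would do as well. As far as these compounds go, it is equally open whether the same gain would hold if the phenyl sulfone end of the molecule carried another group, such as a fluorine or a methoxy group.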